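Phenyltriazole series: trifluoromethyl on the phenyl ring

The source may report more compounds than this note shows. Statements on the series, on what has been measured and on what is new or still open speak of the compounds shown alone.

compound 1 `Cc1c(O)ccc2c1[C@H](Cn1cc(-c3ccccc3)nn1)[C@@]13CC(=O)[C@@](C)(CC[C@@H]21)C3` — in a functional assay on MCF7 cells (Homo sapiens) for cytotoxicity, read by MTT assay, with a stated time of 4 days (a lower number here means a stronger inhibitor, a higher number a weaker inhibitor), compound 1 gives only a limit, > 20000 nM.
compound 2 `Cc1ccc(S(=O)(=O)Oc2ccc3c(c2C)[C@H](Cn2cc(-c4ccccc4)nn2)[C@@]24CC(=O)[C@@](C)(CC[C@@H]32)C4)cc1` — in this assay compound 2 gives only a limit, > 20000 nM.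
compound 3 `C=C1C[C@]23C[C@@]1(O)CC[C@@H]2c1cccc(C)c1[C@@H]3Cn1cc(-c2ccc(Br)cc2)nn1` — in this assay compound 3 gives only a limit, > 20000 nM.

Compound 1 stands at the limit of this assay, as do all values shown (the limit of > 20000 nM in this assay, at which 3 of the 3 values shown sit). Going by the values given here, the single one-place step, a step that the two limits leave unreadable from compound 1 to compound 2, lies between two limits and cannot be read. Compound 4 `Cc1c(O)ccc2c1[C@H](Cn1cc(-c3ccc(C(F)(F)F)cc3)nn1)[C@@]13CC(=O)[C@@](C)(CC[C@@H]21)C3` differs from compound 1 by trifluoromethyl in place of hydrogen on an aromatic carbon. Among the compounds with values here, no measured step touches this phenyl ring; compound 3, whose phenyl ring also carries a substituent, gives only a limit. The step that the limit leaves unreadable from compound 1 to compound 4 is therefore expected to be nothing readable beyond the scatter. Compound 4 is expected at 30000 nM, range 8000 nM to 100000 nM, most likely again a limit.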

Compound 4, half-maximal inhibitory concentration: > 20000 nM
Compound 4: only a limit was reported; the forecaster's own chance of this, stated with the estimate: 80%; the middle value is on the limit's open side.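

Going by these compounds alone, compound 4 stands at > 20000 nM as a limit, and with compound 1 also at a limit, no step between them can be read. The compounds shown leave open whether any change on this series gives a number rather than a limit: the limit of > 20000 nM in this assay, at which 4 of the 4 values shown sit.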